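Cyclohexenyl for Phenyl on an Inactive Diarylamine Nitrile

The source may hold more compounds than are shown below. What is called first, only, known or untested is meant among the compounds shown, and "the series" means these compounds.

Compound 2 `CCN(c1ccc(C#N)c(Cl)c1)c1cc(-c2ccccc2)ccc1C` was tested in a functional assay on VCaP cells (Homo sapiens) for antiproliferative activity, read by CCK-8 assay, with a stated time of 6 days; a higher number here means a weaker inhibitor, a lower number a stronger inhibitor. In this assay compound 2 gives > 30000 nM, which is a limit of the assay and not a number. Compound 1 `N#Cc1ccc(N2CCc3cc(-c4cnc5ccccc5c4)ccc3C2)cc1C(F)(F)F` gives > 30000 nM in this assay, again a limit. Compound 3 `CCN(c1cccc(-n2ccnc2)c1)c1ccc(C#N)c(C(F)(F)F)c1` gives > 30000 nM in this assay, also a limit. Compound 2 thus stands where every value shown stands, at the limit of > 30000 nM in this assay, at which 3 of the 3 values shown sit. Compound 4 `CCN(c1ccc(C#N)c(Cl)c1)c1cc(C2=CCCCC2)ccc1C` differs from compound 2 by cyclohex-1-en-1-yl in place of phenyl on an aromatic carbon. For the measured compounds named here, with no measured step between compounds to lean on, the step of a number no higher from compound 2 to compound 4 (the limit leaves the size open) is expected to be none beyond the scatter. Compound 4 is therefore expected to give about 30000 nM in this assay, within 10000 nM to 100000 nM, and most likely to be reported only as a limit.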

Compound 4, half-maximal inhibitory concentration: 20000 nM
The estimate for compound 4 lay 1.5-fold (0.18 log units) above the measured number, within the range that was stated.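

In this assay compound 4 gives 20000 nM, a number and not a limit, so cyclohex-1-en-1-yl at this position, meta to a large group and para to a methyl group, brings the read-out within the measured range. The change reads as an at least 1.5-fold lower number from compound 2 to compound 4 (0.17 log units; that floor lies within the scatter), and on that floor alone it shows no gain beyond the scatter. The other compounds shown stay at a limit of the assay: the limit of > 30000 nM in this assay, at which 3 of the 4 values shown sit.

The compounds shown leave open how far the true step reaches. They also leave open whether a saturated cyclohexyl here, or an amine or a carboxylic acid on the cyclohex-1-en-1-yl, would give a lower number.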